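Replacing Cyclohexyl with 4-Fluorophenyl on the Ring Amine

A few compounds are considered here, and "the series" means these few. Any claim that something is new, unique, unknown or untested is made for them only; others in the source may bear on it.

Measured in a functional assay, with a stated time of 40 min; on this read-out lower numbers stand for stronger inhibition and higher numbers for weaker inhibition:
- compound 1 `O=c1oc(-c2ccccc2)nn1CCCCN1CCN(C2CCCCC2)CC1` gives 69.3 ug/mL
- compound 2 `COc1cc2c(cc1OC)CN(CCCCn1nc(-c3ccccc3)oc1=O)CC2` gives 21 ug/mL
- compound 3 `O=C1CCc2ccccc2N1CCCCN1CCN(C2CCCCC2)CC1` gives 35.8 ug/mL

Compound 3, at 35.8 ug/mL, lies within the scatter of both compound 1 and compound 2. Compound 4 `O=C1CCc2ccccc2N1CCCCN1CCN(c2ccc(F)cc2)CC1` differs from compound 3 at a single place: 4-fluorophenyl in place of cyclohexyl on an amine nitrogen in a ring. This puts 4-fluorophenyl in place of cyclohexyl on an amine nitrogen in a ring. Among the compounds with values here, no measured pair of compounds shows this exchange, so the data give no direct guide. In this assay no change beyond the scatter is expected. The expected step is a 1.2-fold lower number from compound 3 to compound 4 (0.08 log units; within the scatter). Compound 4 is estimated at 30 ug/mL, with a range of 12 ug/mL to 75 ug/mL.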

Compound 4, half-maximal inhibitory concentration: 21.3 ug/mL
Beside the measured number, compound 4's estimate is 1.4-fold (0.15 log units) above it; the range from low to high includes it.
By their numbers in this assay, from the lowest: compounds 2, 4, 3 and 1 (each within the scatter of the next, the first and the last beyond it).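

In this assay, putting 4-fluorophenyl in place of cyclohexyl on an amine nitrogen in a ring gives a 1.7-fold lower number from compound 3 to compound 4 (0.23 log units; within the scatter). Within the data shown here, this single pair is the first direct reading at this position, and it shows that the aromatic and non-aromatic six-membered rings cannot be told apart here. Nothing available bears on this result.

As far as these compounds go, it remains open whether a pyridyl ring, a benzyl group or a carboxylic acid at this place would shift the number beyond the scatter. From the compounds shown here alone, it also remains open whether the same exchange on the core of compound 1 would give a similar step.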